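Methyl to ethyl on the sulfanyl ring

The source may report more compounds than this note shows. Statements on the series, on what has been measured and on what is new or still open speak of the compounds shown alone.

Compound 1 `Cc1ccc(SCc2ccc(/C=C/C(=O)Nc3ccccc3N)cc2)cc1`: 25.5%
Compound 2 `CC(C)(C)c1ccc(SCc2ccc(C(=O)Nc3ccccc3N)cc2)cc1`: 9.73%
Compound 3 `Nc1ccccc1NC(=O)c1ccc(CSc2ccc(Cl)cc2)cc1`: 19.2%

In a functional assay on HeLa cells (Homo sapiens) for inhibition, read by CCK-8 assay, with a stated time of 72 h, tested at 2 uM (on this read-out lower numbers stand for less inhibition of growth and higher numbers for more inhibition of growth at the one concentration tested), compound 1 gives the highest of the three numbers. Compound 3 sits nearest to it, within the scatter, while compound 2 lies furthest, beyond the scatter. The unmeasured compound 4 `CCc1ccc(SCc2ccc(/C=C/C(=O)Nc3ccccc3N)cc2)cc1` differs from compound 1 by methyl in place of hydrogen on a saturated chain carbon bound to an aromatic carbon. Among the compounds with values here, the only measured step that alters the same ring is a number 9.5 percentage points higher from compound 2 to compound 3 (within the scatter), and it concerns a different pair of groups. Within the data shown here, no measured step sets methyl against ethyl on that ring. Compound 4 is therefore expected to stay close to compound 1, with a number 1.5 percentage points higher from compound 1 to compound 4 (within the scatter) falling within the scatter. The estimate for compound 4 is 27%, between 15% and 40%.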

Compound 4, percent growth inhibition at one concentration: 3.96%
Estimate against measurement, compound 4: 23 percentage points above; the whole stated range lies above it.
By their numbers in this assay, from the lowest: compounds 4, 2, 3 and 1 (each within the scatter of the next, the first and the last beyond it).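

Going from 4-methylphenyl to 4-ethylphenyl gives in this assay a number 21.5 percentage points lower from compound 1 to compound 4 (beyond the scatter) and so shows that one added methyl on this saturated chain carbon is enough to change the read-out beyond the scatter. The earlier step of a number 9.5 percentage points higher from compound 2 to compound 3 (within the scatter) had shown no such change, and it concerned other groups on another core. Nothing available bears on the reason for this drop.

The compounds shown leave open how a propyl chain, a methoxy group or an amine in place of the ethyl would read. They also leave open whether the same methyl-to-ethyl change on the core of compound 2 would give a similar step.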